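Trading a chloro-cyano ring for a methylpyridine

The source may hold more compounds than are shown below. What is called first, only, known or untested is meant among the compounds shown, and "the series" means these compounds.

Three compounds sharing one core have numbers in a functional assay on MCF7 cells (Homo sapiens) for cytotoxicity, read by CellTiter-Glo, with a stated time of 5 days; a higher number here means a weaker inhibitor, a lower number a stronger inhibitor. Compound 1 (`CC/C(=C(/c1ccc(/C=C/C(=O)O)cc1)c1ccc2[nH]ncc2c1)c1ccccc1C#N`) gives 12 nM, compound 2 (`CC/C(=C(/c1ccc(/C=C/C(=O)O)cc1)c1ccc2[nH]ncc2c1)c1ccc(C#N)cc1C`) gives 5 nM, and compound 3 (`CC/C(=C(/c1ccc(/C=C/C(=O)O)cc1)c1ccc2[nH]ncc2c1)c1ccc(C#N)cc1Cl`) gives 4 nM. For the measured compounds named here, compound 3 therefore sits level with compound 2 and clearly under compound 1, the one number of the three that stands apart.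

Compound 4 (`CC/C(=C(/c1ccc(/C=C/C(=O)O)cc1)c1ccc2[nH]ncc2c1)c1cccnc1C`) has not yet been measured. It puts 2-methylpyridin-3-yl in place of 2-chloro-4-cyanophenyl on a double-bonded chain carbon bound to a double-bonded chain carbon and a saturated chain carbon.

Going by the values given here, three measured steps bear on this swap. Changes at this same place gave a 2.4-fold lower number from compound 1 to compound 2 (0.38 log units; beyond the scatter) and a 3.0-fold lower number from compound 1 to compound 3 (0.48 log units; beyond the scatter), both modest, while chloro in place of methyl gave a 1.3-fold lower number from compound 2 to compound 3 (0.10 log units; within the scatter). None of the tested compounds lacks the nitrile or has a hetero atom in this ring, so the new ring is an extrapolation. Like compound 1 at 12 nM, compound 4 carries only one group on its ring, so a move back up seems likelier than a further fall. The expected change is a 3.8-fold higher number from compound 3 to compound 4 (0.57 log units; beyond the scatter), a modest rise in the number. For compound 4 the estimate is 15 nM, with an expected range of 5 nM to 50 nM.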

Compound 4, half-maximal inhibitory concentration: 200 nM
The estimate for compound 4 lay 13-fold (1.12 log units) below the measured number; the measured number lies above the stated range.
By their numbers in this assay, from the lowest: compounds 3 and 2 (each within the scatter of the next); then compound 1; then compound 4.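

In this assay, the ring on this double-bonded chain carbon proves far less forgiving than the three earlier compounds suggested: 2-methylpyridin-3-yl in place of 2-chloro-4-cyanophenyl gave a 50-fold higher number from compound 3 to compound 4 (1.70 log units; beyond the scatter), and in place of 4-cyano-2-methylphenyl it gave a 40-fold higher number from compound 2 to compound 4 (1.60 log units; beyond the scatter). Even in place of 2-cyanophenyl, which also carries a single group on its ring, it gave a 17-fold higher number from compound 1 to compound 4 (1.22 log units; beyond the scatter), so carrying one group does not by itself set the number, and the three nitrile-bearing, all-carbon rings now stand together, well apart from this one. Nothing shown here gives a reason for this rise.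

The swap removes the nitrile and brings a nitrogen atom into the ring in a single move, so the compounds shown cannot say how much of the rise belongs to each change. A plain 2-methylphenyl ring, which loses the nitrile but keeps an all-carbon ring, and a methylpyridine ring that keeps a nitrile would pull the two changes apart.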